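The compounds below may be only part of what the source reports. "The series", "measured", "known", "first", "only" and "open" are said of these compounds alone.

Measured in an ADME assay on L02 cells (Homo sapiens) for inhibition, read by CCK-8 assay, with a stated time of 48 h; a lower number here means a stronger inhibitor of growth, a higher number a weaker inhibitor of growth:
- compound 1 `Cc1ccccc1Nc1nc(Nc2cc(Cl)ccn2)ncc1Cl`: 41500 nM
- compound 2 `CN1CCN(c2ccc(Nc3ncc(Cl)c(NCc4ccc(C(F)(F)F)cc4)n3)nc2)CC1`: 26200 nM

Compound 2, at 26200 nM, stands within the scatter of compound 1, at 41500 nM, so the two numbers give no order. Both compounds show only weak growth inhibition in this assay.

Next in the series is compound 3 `COc1cccc(CNc2nc(Nc3ccc(N4CCN(C)CC4)cn3)ncc2Cl)c1`, not yet measured. Its change from compound 2 is 3-methoxyphenyl in place of 4-(trifluoromethyl)phenyl on a saturated chain carbon bound to a nitrogen on an aromatic ring. The same difference can be read as 4-(trifluoromethyl)benzyl to 3-methoxybenzyl.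

For the measured compounds named here, no measured pair isolates a change at this place, so the data give no direct guide to its size or direction. Going by the values given here, the only anchors are compound 2 at 26200 nM and the structurally more distant compound 1 at 41500 nM. On that basis, no change beyond the scatter is expected. The estimated step is a 1.1-fold higher number from compound 2 to compound 3 (0.06 log units; within the scatter).

For compound 3 the expected value is 30000 nM, with an estimated range from 12000 nM to 70000 nM.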

Compound 3, concentration for 50% growth inhibition: 16200 nM
The estimate for compound 3 lay 1.9-fold (0.27 log units) above the measured number, within the range that was stated.
By their numbers in this assay, from the lowest: compounds 3, 2 and 1 (each within the scatter of the next, the first and the last beyond it).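

At this place the series now has its first measured pair: in this assay, 4-(trifluoromethyl)benzyl to 3-methoxybenzyl on the shared core gives a 1.6-fold lower number from compound 2 to compound 3 (0.21 log units; within the scatter) and so sets no order between the two compounds. This exchange alters the substituted phenyl group from one with three fluorine atoms and no hydrogen-bond acceptor to one with an oxygen and a hydrogen-bond acceptor, and the read-out does not separate the pair, so this single change gives no sign that the number depends on which of these two groups is present. No other data shown bear on this result, and the step stands without an explanation.

From the compounds shown here alone, a single exchange alters both the substituent and its place on the phenyl ring, so the two parts of the change cannot be told apart, and it remains open whether any group on this chain carbon can move the number beyond the scatter. An unsubstituted benzyl, a longer chain such as phenethyl, or a benzyl carrying a carboxylic acid would test how far this place tolerates change.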